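Methyl to isopropyl on compound 1

The compounds below may be only part of what the source reports. "The series", "measured", "known", "first", "only" and "open" are said of these compounds alone.

Of the compounds shown here, three have been measured in a physicochemical assay for solubility, at pH 6.6; a higher number here means a more soluble compound, a lower number a less soluble compound. Compound 1 `CC(c1ccccc1)c1nc2c(C(F)(F)F)cccc2c(C(=O)O)c1O` gives 1550 ug/mL. Compound 2 `O=C(O)c1c(O)c(C2(c3ccccc3)CC2)nc2c(C(O)(C(F)(F)F)C(F)(F)F)cccc12` gives 1500 ug/mL, within the scatter of compound 1, so these two stand level at the top of the set. Compound 3 `CCC(c1ccccc1)c1nc2c(C(F)(F)F)cccc2c(C(=O)O)c1O` gives 600 ug/mL, and compound 1 stands above it by more than the scatter.

The next compound, not yet measured, is compound 4 `CC(C)C(c1ccccc1)c1nc2c(C(F)(F)F)cccc2c(C(=O)O)c1O`. The change is isopropyl in place of methyl on a saturated chain carbon bound to two aromatic carbons.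

Among the compounds with values here, one measured step bears directly on this change: a 2.6-fold lower number from compound 1 to compound 3 (0.41 log units; beyond the scatter). There, methyl replaces hydrogen on a saturated chain carbon, and the chain grows at the same place as in compound 4. Compound 2 differs from compound 1 in more than one place and offers no clean comparison. A single step is thin evidence, and the data do not show whether the trend carries on. Given a 2.6-fold lower number from compound 1 to compound 3 (0.41 log units; beyond the scatter), a fall in this assay somewhat larger than that modest step is expected. The expected step is a 4.4-fold lower number from compound 1 to compound 4 (0.65 log units; beyond the scatter). Compound 4 is estimated at 350 ug/mL, with an expected range of 120 ug/mL to 900 ug/mL.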

Compound 4, solubility: 30 ug/mL
The estimate for compound 4 lay 12-fold (1.07 log units) above the measured number; measured number below the stated range.
By their numbers in this assay, from the lowest: compound 4; then compound 3; then compounds 2 and 1 (each within the scatter of the next).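

At this position, on a saturated chain carbon bound to two aromatic carbons, the number in this assay does not fall evenly as the chain grows: the change from methyl to isopropyl gives a 52-fold lower number from compound 1 to compound 4 (1.71 log units; beyond the scatter) and so goes far past the earlier modest step. Most of that fall sits in the last addition, methyl in place of hydrogen on a saturated chain carbon bound to two saturated chain carbons, which gives a 20-fold lower number from compound 3 to compound 4 (1.30 log units; beyond the scatter) and is large, whereas a 2.6-fold lower number from compound 1 to compound 3 (0.41 log units; beyond the scatter) is modest; within compounds 1, 3 and 4 nothing goes against this steepening, and compound 2 differs from them in more than one place and cannot test it. No measurement here speaks to why the number drops so sharply at this place.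

Within the data shown here, three compounds give only two successive steps along this chain, so it remains open whether the large drop belongs to branching as such or to chain length, which a straight propyl chain at the same place would separate. Also open, going by these compounds, is whether an amine carried on this chain would give a number nearer compound 1 or nearer compound 4.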